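A few compounds are considered here, and "the series" means these few. Any claim that something is new, unique, unknown or untested is made for them only; others in the source may bear on it.

For the measured compounds named here, compound 2 `CO/N=C(\CCN1CCN(c2ccccn2)CC1)c1ccc(Cl)cc1` gives 87% in a functional assay on HEK293 cells with D(4) dopamine receptor (Homo sapiens) as the target, read by FLIPR (a lower number here means a smaller maximal response, a higher number a larger maximal response), the highest of the three numbers measured so far, though its distance from each of the other two lies within the scatter. Compound 1 `CO/N=C(\CCN1CCN(c2ccccn2)CC1)c1ccccc1Cl` gives 79% in this assay, and compound 3 `CO/N=C(\CCN1CCN(c2ccccn2)CC1)c1ccc(Cl)c(Cl)c1` gives 79%. The measured steps all concern the chlorine pattern on the phenyl ring: a number 8 percentage points higher from compound 1 to compound 2 (within the scatter), a number 8 percentage points lower from compound 2 to compound 3 (within the scatter) and no change at the digits printed from compound 1 to compound 3 (within the scatter). None of them moves the maximal response beyond the scatter.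

Compound 4 `CO/N=C(\CCN1CCN(c2ccccn2)CC1C)c1ccc(Cl)cc1` differs from compound 2 in another part of the shared core: methyl in place of hydrogen on a saturated ring carbon. Going by the values given here, no measured step touches that saturated ring, so nothing here bears directly on this change. The three values sit close together, and on that basis no step beyond the scatter is expected for compound 4 in this assay, that is a number 3 percentage points lower from compound 2 to compound 4 (within the scatter). Compound 4 is therefore estimated at 84%, with a range from 66% to 100%.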

Compound 4, largest response reached (reported as efficacy), in percent of the reference or control that the assay uses: 60%
Beside the measured number, compound 4's estimate is 24 percentage points above it; measured number below the stated range.
By their numbers in this assay, from the lowest: compound 4; then compounds 1, 3 and 2 (each within the scatter of the next).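

In this assay, the saturated ring responds where the phenyl ring did not: methyl in place of hydrogen gives a number 27 percentage points lower from compound 2 to compound 4 (beyond the scatter) and so moves the maximal response beyond the scatter, whereas every step among the chlorine patterns of compound 1, compound 2 and compound 3 stayed within it. For the compounds shown here, the change is small, since only one carbon enters, on a saturated ring carbon next to the ring nitrogen, so this position tolerates less than the earlier steps suggested. No available evidence explains the drop.

The compounds shown leave open whether a larger group at this carbon, such as ethyl or hydroxymethyl, would lower the response further, or whether a hydroxyl would behave differently. They also leave open whether methyl has the same effect alongside the 2-chlorophenyl or 3,4-dichlorophenyl group.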